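Working notes: from compound 2 to compound 3

The source may hold more compounds than are shown below. What is called first, only, known or untested is meant among the compounds shown, and "the series" means these compounds.

Measured so far:
- compound 1 `O=C(O)COc1ccc(NCc2ccc(Cl)c(-c3ccccc3)c2)cc1F` gives 2.74
- compound 2 `Cc1ccccc1-c1cccc(CNc2ccc(OCC(=O)O)c(F)c2)c1` gives 2.41

In a physicochemical assay for lipophilicity, read by HPLC, in phosphate buffer, measured as octanol-water partition, at pH 7.4, tested at 100 uM (on this read-out lower numbers stand for lower lipophilicity and higher numbers for higher lipophilicity), compound 2 gives 2.41 and is the lower of the two measured compounds. Compound 1 stands higher at 2.74 and the gap between them lies beyond the scatter.

The next entry is compound 3 `Cc1ccc(-c2cccc(CNc3ccc(OCC(=O)O)c(F)c3)c2)c(Cl)c1`, which is to be measured in this assay. Relative to compound 2 it has 2-chloro-4-methylphenyl in place of 2-methylphenyl on an aromatic carbon and this carbon sits meta to a large group.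

Within the data shown here, no measured pair differs in one place only, so no direct precedent exists for this change. The expectation therefore rests on the structural change alone and remains uncertain. A moderate rise is expected, probably a little beyond the scatter. The estimated size of the step is a number 0.44 log units higher from compound 2 to compound 3 (beyond the scatter) and its expected direction is upward. For compound 3 the expected value is 2.85 within an estimated range (2.5 to 3.2).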

Compound 3, distribution coefficient: 3.24
Compound 3: middle estimate off by 0.39 log units, on the low side; the measured number lies above the stated range.
By their numbers in this assay, from the lowest: compound 2; then compound 1; then compound 3.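

Working notes after compound 3: in this assay, exchanging one aromatic group for another, meta to a large group, gives a number 0.83 log units higher from compound 2 to compound 3 (beyond the scatter), the only step in the series so far between compounds that differ in one place, and it shows that the read-out at this position responds to a change in the substituents on the outer aromatic ring. The change itself is small by the counted features: the group goes from 7 to 8 heavy atoms, the ring stays a six-membered aromatic ring of carbon only, neither group carries hydrogen-bond donors or acceptors, and neither has a net charge. No supporting measurement bears on the origin of this step.

The single step changes the chlorine and the methyl together, so the compounds shown leave open how much of it belongs to the chlorine and how much to the altered methyl placement. It also remains open how this position would respond to a ring bearing a methoxy group, a nitrile or an amine, since all the groups shown here carry only carbon and halogen.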